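Compound 2 to compound 3: one group exchanged

A few compounds are considered here, and "the series" means these few. Any claim that something is new, unique, unknown or untested is made for them only; others in the source may bear on it.

In a functional assay on HepG2 cells (Homo sapiens) for antiproliferative activity, read by MTT assay, with a stated time of 24 h (on this read-out lower numbers stand for stronger inhibition and higher numbers for weaker inhibition), compound 1 `C=CCOc1ccc2c(=O)c(-c3cc(OC)c(OC)cc3OC)coc2c1` gives 3450 nM as a measured number. Compound 2 `COc1cc(OC)c(-c2coc3cc(OCC(=O)c4cccc(C(F)(F)F)c4)ccc3c2=O)cc1OC` stands at > 10000 nM as a limit of the assay and not a number. Compound 3 `COc1cc(OC)c(-c2coc3cc(OCc4ccccc4F)ccc3c2=O)cc1OC` differs from compound 2 in a single group: 2-fluorophenyl in place of (3-(trifluoromethyl)phenyl)carbonyl on a saturated chain carbon bound to an oxygen on an aromatic ring with 2-fluorophenyl in place of (3-(trifluoromethyl)phenyl)carbonyl on a saturated chain carbon bound to an oxygen on an aromatic ring. Among the measured compounds shown here, the only measured step that bears on this is an at least 2.8-fold higher number from compound 1 to compound 2 (0.46 log units; beyond the scatter) and it lies beyond the scatter. It brought in the group that now leaves. For the measured compounds named here, no measured step shows what 2-fluorophenyl does. Compound 3 is therefore expected to move back towards compound 1 at 3450 nM on this read-out. The expected change is towards a lower number, estimated as an at least 2.0-fold lower number from compound 2 to compound 3 (0.30 log units; that floor lies within the scatter) from that single step. For compound 3 the estimate is 5000 nM with an expected range from 1800 nM to 10000 nM as its upper end.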

Compound 3, half-maximal inhibitory concentration: 1280 nM
Compound 3: the middle estimate sits 3.9-fold (0.59 log units) above what was measured; the measured number lies below the stated range.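

In this assay, the saturated chain carbon bound to an oxygen on an aromatic ring can carry a six-membered aromatic ring without the loss seen earlier, with an at least 7.8-fold lower number from compound 2 to compound 3 (0.89 log units; beyond the scatter); the earlier loss therefore does not extend to every group holding such a ring. Measured against vinyl, 2-fluorophenyl goes further, with a 2.7-fold lower number from compound 1 to compound 3 (0.43 log units; beyond the scatter), so a change at this place can improve on compound 1 as well as lose ground from it. The value of compound 2 is a limit of the assay and not a number, so the step out of it gives only a floor: the limit of > 10000 nM in this assay, at which 1 of the 3 values shown sits.

The compounds shown do not separate the effect of the ring from that of its fluorine, nor that of the carbonyl from that of the trifluoromethyl, which leave together. On these data alone, what a plain phenyl, an amine or a carboxylic acid on the same chain carbon would give stays open.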